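Sulfonyl substituent changes on a shared benzoxazole sulfonamide core

A few compounds are considered here, and "the series" means these few. Any claim that something is new, unique, unknown or untested is made for them only; others in the source may bear on it.

Measured so far:
compound 1, `O=S(=O)(Nc1ccc2oc(-c3ccccc3)nc2c1)c1ccccc1O`: 33000 nM
compound 2, `O=S(=O)(Nc1ccc2oc(-c3ccccc3)nc2c1)c1cccs1`: 97000 nM

Both compounds carry the same core and differ only in the group on the sulfonyl sulfur. In an ADME assay on HEK293 cells (Homo sapiens) for cytotoxicity, read by resazurin assay, with a stated time of 48 h (a higher number here means that more compound is tolerated, a lower number that less compound is tolerated), compound 1 gives 33000 nM and compound 2 gives 97000 nM. Going by the values given here, the only measured step, a 2.9-fold higher number from compound 1 to compound 2 (0.47 log units; beyond the scatter), shows that swapping the sulfonyl substituent has moved the number in this assay by more than the scatter, and compound 2 stands at the higher of the two numbers.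

Compound 3, `CS(=O)(=O)Nc1ccc2oc(-c3ccccc3)nc2c1`, is not yet measured. It differs from compound 2 as follows: methyl in place of thiophen-2-yl on a sulfonyl sulfur. Among the compounds with values here, the one measured step bears on this change only loosely, since it too alters the group on the sulfonyl sulfur, and it was modest in size. Nothing measured separates the effect of an aromatic group from that of a small chain at this position, so no direction is assumed beyond the scatter; the step of a 1.0-fold higher number from compound 2 to compound 3 (0.01 log units; within the scatter) is expected to stay small. For compound 3 the estimate in this assay is 100000 nM, with a range from 40000 nM to 250000 nM.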

Compound 3, half-maximal cytotoxic concentration: > 100000 nM
Compound 3 gave a limit, no number; the forecaster's own chance of this, stated with the estimate: 35%; the middle value lies on the limit itself.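

With methyl on the sulfonyl sulfur, compound 3 reaches a limit of this assay and gives no number: the limit of > 100000 nM in this assay, at which 1 of the 3 values shown sits.

Against thiophen-2-yl, the change gives an at least 1.0-fold higher number from compound 2 to compound 3 (0.01 log units; that floor lies within the scatter), so this floor does not place the methyl and thiophen-2-yl groups in any order. Against 2-hydroxyphenyl, the reading is firmer, with an at least 3.0-fold higher number from compound 1 to compound 3 (0.48 log units; beyond the scatter); an aromatic ring on the sulfonyl sulfur is therefore not required for a high number here, and the lower reading of compound 1 now stands apart from both other compounds by more than the scatter.

Going by these compounds, how far compound 3 lies past its limit stays open, and with it whether compound 2 and compound 3 differ at all. Also open, on these data alone, are how an amine, a carboxylic acid or a longer chain on the sulfonyl sulfur would read, and whether the lower number of compound 1 goes with its hydroxyl or with the phenyl ring itself, a question that a plain phenyl group at this place would separate.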